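Methoxy in Place of Piperidin-1-yl: Expected Tolerance Shift

The compounds below may be only part of what the source reports. "The series", "measured", "known", "first", "only" and "open" are said of these compounds alone.

Going by the values given here, compound 3 `OC[C@H]1O[C@@H](n2cnc3c(CN4CCCCC4)ncnc32)[C@H](O)[C@@H]1O` holds the only plain number in a functional assay on Huh-7 cells (Homo sapiens) for cytotoxicity, read by MTT assay, with a stated time of 3 days; a higher number here means that more compound is tolerated, a lower number that less compound is tolerated: compound 3 gives 87000 nM. Compound 1 `OC[C@H]1O[C@@H](n2cnc3c(CSc4ccccn4)ncnc32)[C@H](O)[C@@H]1O` sits at a limit of this assay, > 100000 nM. Compound 2 `OC[C@H]1O[C@@H](n2cnc3c(Cn4cccn4)ncnc32)[C@H](O)[C@@H]1O` likewise sits at a limit, > 250000 nM. Compound 4 `COCc1ncnc2c1ncn2[C@@H]1O[C@H](CO)[C@@H](O)[C@H]1O` differs from compound 3 by methoxy in place of piperidin-1-yl on a saturated chain carbon bound to an aromatic carbon. Among the compounds with values here, two measured steps bear on this change: an at least 1.1-fold lower number from compound 1 to compound 3 (0.06 log units; that floor lies within the scatter) and an at least 2.8-fold lower number from compound 2 to compound 3 (0.45 log units; beyond the scatter). The entry of piperidin-1-yl thus went with lower numbers, clearly so against 1H-pyrazol-1-yl, so its departure is expected to raise the number. A step of a 1.7-fold higher number from compound 3 to compound 4 (0.24 log units; within the scatter) is expected. Compound 4 is therefore estimated to give 150000 nM, within 60000 nM to 400000 nM, with a real chance that this assay reports only a limit.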

Compound 4, half-maximal cytotoxic concentration: > 100000 nM
Compound 4: a limit, no number; the forecaster's own chance of this, stated with the estimate: 50%; the middle value does not contradict the limit.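

Setting methoxy in place of piperidin-1-yl at this position gives, in this assay, an at least 1.1-fold higher number from compound 3 to compound 4 (0.06 log units; that floor lies within the scatter). Compound 4 thus shows that a group without a ring on this saturated chain carbon also ends at a limit and gives no plain number: the limit of > 100000 nM in this assay, at which 2 of the 4 values shown sit. The steps from compounds 1 and 2 to compound 4 cannot be read, so methoxy cannot be ranked against (pyridin-2-yl)sulfanyl or 1H-pyrazol-1-yl. Still open, from the compounds shown here alone, is whether an open-chain amine such as dimethylamino on this carbon would give a plain number, as piperidin-1-yl does in compound 3.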